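Replacing Cyclopentyl with Isobutyl: Compound 1 to Compound 4

A few compounds are considered here, and "the series" means these few. Any claim that something is new, unique, unknown or untested is made for them only; others in the source may bear on it.

Compound 1 `O=C(O)CCNC(=O)c1ccc(C(Oc2ccc(-n3cc(C(F)(F)F)cn3)cc2)C2CCCC2)cc1` holds the only plain number shown in an ADME assay on microsomes from liver (Rattus norvegicus) for metabolic stability (on this read-out lower numbers stand for slow clearance and higher numbers for fast clearance), where compound 1 gives 31 mL/min/kg. Compound 2 `O=C(O)CCNC(=O)c1ccc(C(Oc2ccc(-n3cc(C(F)(F)F)cn3)cc2)C2CC2)cc1` gives < 25 mL/min/kg in this assay, which is a limit of the assay rather than a number. Compound 3 `CCCC(Oc1ccc(-n2cc(C(F)(F)F)cn2)cc1)c1ccc(C(=O)NCCC(=O)O)cc1` gives < 36 mL/min/kg in this assay, also a limit. Going by the values given here, the one readable step is an at least 1.2-fold lower number from compound 1 to compound 2 (0.09 log units; that floor lies within the scatter); the steps from compound 1 to compound 3 and from compound 2 to compound 3 cannot be read from their limits. Compound 4 `CC(C)CC(Oc1ccc(-n2cc(C(F)(F)F)cn2)cc1)c1ccc(C(=O)NCCC(=O)O)cc1` carries isobutyl in place of cyclopentyl on a saturated chain carbon bound to an aromatic carbon and an oxygen on an aromatic ring. The nearest measured step, the cyclopentyl-to-cyclopropyl change, stayed within the scatter, so compound 4 is expected to show no clear step beyond the scatter, an estimated 1.1-fold lower number from compound 1 to compound 4 (0.04 log units; within the scatter). Compound 4 is therefore estimated at 28 mL/min/kg, between 15 mL/min/kg and 50 mL/min/kg.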

Compound 4, clearance: 46 mL/min/kg
Compound 4: the middle estimate sits 1.6-fold (0.22 log units) below what was measured, within the range that was stated.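

In this assay, this position now has a second plain number, and the change from the cyclopentyl ring to open-chain isobutyl reads as a 1.5-fold higher number from compound 1 to compound 4 (0.17 log units; within the scatter). The reading of an at least 1.2-fold higher number from compound 3 to compound 4 (0.10 log units; that floor lies within the scatter) is only a floor, because its starting compound stands at a limit of the assay: the limit of < 36 mL/min/kg in this assay, at which 1 of the 4 values shown sits. The reading of an at least 1.8-fold higher number from compound 2 to compound 4 (0.26 log units; that floor lies within the scatter) is likewise only a floor, because its starting compound stands at a limit of the assay: the limit of < 25 mL/min/kg in this assay, at which 1 of the 4 values shown sits.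

The compounds shown leave open how an amine or a longer chain at this position would read in this assay. They also leave open whether plain numbers in place of the two limits would carry these steps beyond the scatter.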